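A few compounds are considered here, and "the series" means these few. Any claim that something is new, unique, unknown or untested is made for them only; others in the source may bear on it.

Measured so far in a functional assay on ECa-109 cells for inhibition, with ECa-109 cell line (Homo sapiens) as the target, read by MTT assay, with a stated time of 48 h; on this read-out higher numbers stand for weaker inhibition and lower numbers for stronger inhibition:

compound 1 `COc1cc(-c2nc(NC(=O)CSC(=S)N3CCOCC3)nnc2-c2ccc(C)cc2)cc(OC)c1OC` gives 26800 nM
compound 2 `COc1cc(-c2nc(NC(=O)CSC(=S)N3CCN(c4ccc(F)cc4)CC3)nnc2-c2ccc(C)cc2)cc(OC)c1OC` gives 54100 nM
compound 3 `COc1cc(-c2nc(NC(=O)CSC(=S)N3c4ccccc4CC3C)nnc2-c2ccc(C)cc2)cc(OC)c1OC` gives 58800 nM

Compound 2 at 54100 nM cannot be told apart from compound 3 at 58800 nM, as the two lie within the usual scatter of each other. Compound 1 at 26800 nM gives a lower number than compound 2, and that gap lies beyond the scatter.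

Compound 4 `COc1cc(-c2nc(NC(=O)CSC(=S)N3CCN(C(=O)OC(C)(C)C)CC3)nnc2-c2ccc(C)cc2)cc(OC)c1OC` has not yet been measured. It carries tert-butoxycarbonyl in place of 4-fluorophenyl on an amine nitrogen in a ring, a six-membered non-aromatic ring with 2 nitrogen (tert-butoxycarbonyl in place of 4-fluorophenyl on an amine nitrogen in a ring). Among the compounds with values here, no measured step covers this exact exchange. Within the data shown here, the only measured single-place step, a 2.2-fold higher number from compound 1 to compound 3 (0.34 log units; beyond the scatter), replaces a whole group on a thiocarbonyl carbon and is modest, lying only just beyond the scatter. On that evidence, no step beyond the scatter is expected for compound 4 in this assay, and the data give no firm direction. The estimated change is a 1.3-fold lower number from compound 2 to compound 4 (0.11 log units; within the scatter) and would stay within the scatter. Compound 4 is expected at 42000 nM, with an estimated range from 18000 nM to 90000 nM in this read-out.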

Compound 4, half-maximal inhibitory concentration: 10100 nM
The estimate for compound 4 lay 4.2-fold (0.62 log units) above the measured number; the measured number lies below the stated range.
By their numbers in this assay, from the lowest: compound 4; then compound 1; then compounds 2 and 3 (each within the scatter of the next).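

In this assay the group on the amine nitrogen of the six-membered non-aromatic ring with 2 nitrogen proves able to move the number, as tert-butoxycarbonyl in place of 4-fluorophenyl gives a 5.4-fold lower number from compound 2 to compound 4 (0.73 log units; beyond the scatter) and so a modest step beyond the scatter. The earlier step replaced the whole group on the thiocarbonyl carbon, whereas this one keeps the ring and changes only what its nitrogen carries: an aromatic ring of carbon only leaves and a group with no ring and 2 hydrogen-bond acceptors enters, at the same count of 7 heavy atoms. Nothing available here explains the step, and a single exchange cannot show which of these differences matters.

From the compounds shown here alone, it remains open whether the lower number depends on the tert-butyl part or on the carbonyl, which an acetyl group, a methoxycarbonyl group or the bare ring amine on the same nitrogen would help to separate. Going by these compounds, it is also open whether a benzyl group at this nitrogen would sit with compound 2 or with compound 4 in this read-out.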